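Para Substituent Swaps on a Shared Core: Bromo to Acetyl

This account rests on a few compounds, and the source may have more. Where it says the series, first, only, none or still open, it means among the compounds named here.

Measured compounds:
Compound 1 `Cc1ccc(S(=O)(=O)n2cc(COC3=C/C(=N\c4ccc(Br)cc4)c4ccccc4C3=O)nn2)cc1` gives 9410 nM in a functional assay on NCI-H460 cells (Homo sapiens) for cytotoxicity, read by MTT assay, with a stated time of 72 h; a lower number here means a stronger inhibitor, a higher number a weaker inhibitor.
Compound 2 `Cc1ccc(S(=O)(=O)n2cc(COC3=C/C(=N\c4ccc(F)cc4)c4ccccc4C3=O)nn2)cc1` gives 7360 nM in this assay.
Compound 3 `Cc1ccc(S(=O)(=O)n2cc(COC3=C/C(=N\c4ccccc4)c4ccccc4C3=O)nn2)cc1` gives 7220 nM in this assay.

Compound 1 has the highest number of the three, but its separation from the others is small: a 1.3-fold lower number from compound 1 to compound 2 (0.11 log units; within the scatter), and a 1.3-fold lower number from compound 1 to compound 3 (0.12 log units; within the scatter). The remaining pair is likewise close, with a 1.0-fold lower number from compound 2 to compound 3 (0.01 log units; within the scatter). Taken together, the three compounds show that exchanging bromo for fluoro or for hydrogen on an aromatic carbon of the shared core leaves this assay essentially unchanged.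

Compound 4 `CC(=O)c1ccc(/N=C2\C=C(OCc3cn(S(=O)(=O)c4ccc(C)cc4)nn3)C(=O)c3ccccc32)cc1` is not yet measured. It differs from compound 1 in one place: acetyl in place of bromo on an aromatic carbon. The change sits on an aromatic carbon of a six-membered aromatic ring of carbon only, para to a large group, the same position that carried bromo, fluoro and hydrogen in the measured set. All three steps that bear on this position lay within the scatter, so no reliable direction can be read from them for acetyl, a group that brings more heavy atoms and a hydrogen-bond acceptor to that position. Compound 4 is therefore expected to land near compound 1, with a 1.1-fold lower number from compound 1 to compound 4 (0.04 log units; within the scatter) expected to stay within the scatter. The estimate for compound 4 in this assay is 8500 nM, with a range from 3500 nM to 22000 nM.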

Compound 4, half-maximal inhibitory concentration: 15800 nM
Compound 4: middle estimate off by 1.9-fold (0.27 log units), on the low side, within the range that was stated.
By their numbers in this assay, from the lowest: compounds 3, 2, 1 and 4 (each within the scatter of the next, the first and the last beyond it).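

For the compounds shown here, at this position, on an aromatic carbon para to a large group, acetyl is the first group to give steps beyond the scatter, though both are modest: a 2.2-fold higher number from compound 3 to compound 4 (0.34 log units; beyond the scatter) and a 2.1-fold higher number from compound 2 to compound 4 (0.33 log units; beyond the scatter) in this assay. The position is therefore not wholly indifferent to the group it carries, as the exchanges among bromo, fluoro and hydrogen had suggested, but the acetyl effect is not clean, since compound 1 goes against it with a 1.7-fold higher number from compound 1 to compound 4 (0.23 log units; within the scatter), a step that stays within the scatter. No supporting measurement is available to account for these steps.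

The compounds shown leave open whether the shift belongs to acetyl in particular or would also appear with other groups at the same place, such as an amine, a carboxylic acid, a nitrile or a longer acyl chain such as propanoyl. They also leave open whether a step of this modest size would hold on cell lines other than the one tested here, as all four values come from a single assay.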